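This account rests on a few compounds, and the source may have more. Where it says the series, first, only, none or still open, it means among the compounds named here.

The measured compounds:
Compound 1, `COCCNC(=O)c1cc2cccc(OC)c2oc1=N`: 43%
Compound 2, `COc1cccc2cc(C(=O)NCCCOCCCCOCCCNC(=O)c3cc4cccc(OC)c4oc3=N)c(=N)oc12`: 44%
Compound 3, `CCC(CO)NC(=O)c1cc2cc(Br)ccc2oc1=N`: 4%

All three were tested in an assay on HEK293 cells for displacement of a labelled ligand from adenosine receptor A2b (Homo sapiens), read by scintillation counting, with a stated time of 30 min, tested at 10 uM; on this read-out lower numbers stand for less inhibition and higher numbers for more inhibition at the one concentration tested (going by the name of the read-out). Compound 1 gives 43%, the second highest of the three numbers. Compound 2 gives 44%, a value within the usual scatter of compound 1, so the two cannot be told apart. Compound 3 gives 4%, far below compound 1, a gap beyond the scatter; compound 3 also carries a different core, so this gap cannot be tied to one change.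

Compound 4, `COc1cccc2cc(C(=O)NC(CO)(CO)CO)c(=N)oc12`, is not yet measured. It differs from compound 1 in one place: 2-hydroxy-1,1-bis(hydroxymethyl)ethyl in place of 2-methoxyethyl on an amide-type nitrogen. Among the measured compounds shown here, no single-change step between measured compounds exists, so the expected size must be judged from what is present. Compound 1 and compound 2 share the core of compound 1 and differ only at the amide, yet show values within the scatter of each other, hinting that changes at the amide nitrogen on this core do not move the read-out much. The expected step is a number 8 percentage points lower from compound 1 to compound 4 (within the scatter), a slight drop, not clearly beyond the scatter. The estimate for compound 4 is 35%, with a range from 10% to 58%.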

Compound 4, a percentage reported as inhibition, at one concentration (the size of the read-out at that concentration, not a potency): 28%
Estimate against measurement, compound 4: 7 percentage points above, and the stated range covers the measured number.
By their numbers in this assay, from the lowest: compound 3; then compound 4; then compounds 1 and 2 (each within the scatter of the next).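

In this assay, among the compounds shown here, putting 2-hydroxy-1,1-bis(hydroxymethyl)ethyl in place of 2-methoxyethyl on an amide-type nitrogen gives a number 15 percentage points lower from compound 1 to compound 4 (beyond the scatter) and is the first comparison here in which only one place changes. It shows that the group on this nitrogen can move the read-out, yet the drop is modest: compound 4 still gives 28% with the much larger group in place. Nothing at hand explains why the number falls.

Going by these compounds, this single step changes the size of the group and its hydrogen-bond donors and acceptors together, so their separate contributions remain open. A simple 2-hydroxyethyl chain, an amine or a carboxylic acid on the same nitrogen would help to show which feature of the change goes with the lower number.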